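The source may report more compounds than this note shows. Statements on the series, on what has been measured and on what is new or still open speak of the compounds shown alone.

Compound 1 `COc1cccc(/C=C/C(=O)c2c(OC)cc(OC)cc2OC)c1` gives 5.1% in a functional assay on NCI-H727 cells (Homo sapiens), read by fluorescence and BrdU incorporation, with a stated time of 48 h, tested at 25 uM; a higher number here means a weaker effect of the compound at the concentration tested, a lower number a stronger effect.
Compound 2 `COc1cc(O)c(C(=O)/C=C/c2ccccc2OC)c(OC)c1` gives 14% in this assay.

Compound 1 has the lowest of the two numbers, and compound 2 lies within the scatter of it, so the two show the same strength of effect at the concentration tested. Compound 3 `COc1cc(OC)c(C(=O)/C=C/c2ccc(F)cc2)c(OC)c1` is not yet measured. It differs from compound 1 in one change: 4-fluorophenyl in place of 3-methoxyphenyl on a double-bonded chain carbon bound to a double-bonded chain carbon. For the measured compounds named here, no step between measured compounds gauges this change, so the step of a number 4.9 percentage points higher from compound 1 to compound 3 (within the scatter) is expected to stay within the scatter, in no sure direction. Compound 3 is expected to give 10%, ranging from 2% to 30%.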

Compound 3, a percentage reported as activity, at one concentration (the size of the read-out at that concentration, not a potency): 4.5%
Compound 3: the middle estimate sits 5.5 percentage points above what was measured, within the range that was stated.
By their numbers in this assay, from the lowest: compounds 3, 1 and 2 (each within the scatter of the next).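

In this assay, putting 4-fluorophenyl in place of 3-methoxyphenyl on a double-bonded chain carbon bound to a double-bonded chain carbon gives a number 0.6 percentage points lower from compound 1 to compound 3 (within the scatter). For this pair, then, the read-out at the tested concentration does not depend on keeping 3-methoxyphenyl or its hydrogen-bond acceptor at this position. No measurement shown here accounts for the two groups reading alike.

On these data alone, it remains open whether a phenyl carrying an amine or a carboxylic acid at this place would read the same. The compounds shown also do not separate the change of substituent from its change of place on the ring.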